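Sulfonamide anilides: meta chloro removed from the aniline ring

A few compounds are considered here, and "the series" means these few. Any claim that something is new, unique, unknown or untested is made for them only; others in the source may bear on it.

Three anilides share a core with compound 3 `O=C(Nc1ccc(S(=O)(=O)Nc2cccc(Cl)c2)cc1)c1ccc(Cl)cc1Cl`. Compound 1 `O=C(NS(=O)(=O)c1ccc(NC(=O)c2ccc(Cl)cc2Cl)cc1)c1ccccc1` has in a functional assay on HEK293 cells for agonist activity at probable G-protein coupled receptor 27 (Homo sapiens), read by a luciferase reporter and beta-arrestin recruitment, with a stated time of 10 min (on this read-out lower numbers stand for smaller maximal responses and higher numbers for larger maximal responses), only the record "not determined" (no result reported). Compound 2 `O=C(Nc1ccc(S(=O)(=O)Nc2ccc(Cl)cc2)cc1)c1ccc(Cl)cc1Cl` likewise shows in this assay only "not determined" (no result reported). Among the measured compounds shown here, compound 3 is thus the single compound with a number: in this assay compound 3 gives 40%, and no step between measured compounds is known.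

Compound 4 `O=C(Nc1ccc(S(=O)(=O)Nc2ccccc2)cc1)c1ccc(Cl)cc1Cl` differs from compound 3 by hydrogen in place of chloro on an aromatic carbon, on an aromatic carbon of a six-membered aromatic ring of carbon only, meta to a large group. For the measured compounds named here, with one number in hand and no measured step, only a modest change is expected, if any, and the drop of a number 5 percentage points lower from compound 3 to compound 4 (within the scatter) is estimated to lie within the scatter. For compound 4 the estimate in this assay is 35%, between 15% and 60%.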

Compound 4, largest response reached (Emax), in percent of the reference or control that the assay uses: 100%
The estimate for compound 4 lay 65 percentage points below the measured number, and the stated range ends below it.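

Replacing the chloro on this aromatic carbon, meta to a large group, with hydrogen gives in this assay a number 60 percentage points higher from compound 3 to compound 4 (beyond the scatter). The maximal response therefore depends strongly on what occupies this single position, which a lone number could not show. Nothing at hand accounts for the size of this step.

From the compounds shown here alone, whether a methyl, a methoxy or an amine at this place would keep the response of compound 4 stays open. Also open, going by these compounds, is whether chloro at other places on this ring lowers the response, since compound 2 has no number.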